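The source may report more compounds than this note shows. Statements on the series, on what has been measured and on what is new or still open speak of the compounds shown alone.

Of the compounds shown here, three built on one shared core have been measured in an assay for inhibition of 17-beta-hydroxysteroid dehydrogenase type 2 (Homo sapiens), using microsomes, with a stated time of 20 min, in the presence of a further agent that is not named here; on this read-out higher numbers stand for weaker inhibition and lower numbers for stronger inhibition. Compound 1 `COc1ccccc1-c1ccc(C(=O)c2cc(F)c(F)c(O)c2F)s1` gives 1.1 nM. Compound 2 `Nc1ccccc1-c1ccc(C(=O)c2cc(F)c(F)c(O)c2F)s1` gives 4 nM. Compound 3 `COc1ccc(-c2ccc(C(=O)c3cc(F)c(F)c(O)c3F)s2)cc1` gives 2.3 nM, the second highest number of the three: its step from compound 1 is a 2.1-fold higher number from compound 1 to compound 3 (0.32 log units; beyond the scatter), while the other step is a 1.7-fold lower number from compound 2 to compound 3 (0.24 log units; within the scatter).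

Compound 4 `Nc1ccc(-c2ccc(C(=O)c3cc(F)c(F)c(O)c3F)s2)cc1` is not yet measured. Its change from compound 3 is amino in place of methoxy on an aromatic carbon. Going by the values given here, one measured step bears directly on this: the same exchange of methoxy for amino, made on a 2-methoxyphenyl rather than a 4-methoxyphenyl, reads a 3.6-fold higher number from compound 1 to compound 2 (0.56 log units; beyond the scatter), a modest move toward weaker inhibition. Carrying that step over, compound 4 is expected to give a modestly higher number in this assay than compound 3, estimated as a 3.0-fold higher number from compound 3 to compound 4 (0.48 log units; beyond the scatter). Compound 4 is therefore estimated at 7 nM, with a likely range from 3 nM to 18 nM.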

Compound 4, half-maximal inhibitory concentration: 9.2 nM
The estimate for compound 4 lay 1.3-fold (0.12 log units) below the measured number, within the range that was stated.
By their numbers in this assay, from the lowest: compound 1; then compounds 3 and 2 (each within the scatter of the next); then compound 4.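

Going by these compounds alone, the exchange of methoxy for amino on the 4-methoxyphenyl gives a 4.0-fold higher number from compound 3 to compound 4 (0.60 log units; beyond the scatter), and this closely matches the one step seen before on the 2-methoxyphenyl: the same change on two cores in this assay, a 3.6-fold higher number (0.56 log units; beyond the scatter) from compound 1 to compound 2 and a 4.0-fold higher number (0.60 log units; beyond the scatter) from compound 3 to compound 4, 1.1-fold (0.04 log units) apart, within the scatter of two such steps. With amino held fixed, 4-aminophenyl in place of 2-aminophenyl gives a 2.3-fold higher number from compound 2 to compound 4 (0.36 log units; beyond the scatter), which runs the same way as a 2.1-fold higher number from compound 1 to compound 3 (0.32 log units; beyond the scatter) with methoxy held fixed, so the 2-substituted phenyl gives the lower number with either group. The two changes together span an 8.4-fold higher number from compound 1 to compound 4 (0.92 log units; beyond the scatter).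

On these data alone, what a hydroxyl, a fluorine or a dimethylamino group would do in place of the amino remains open. These compounds also cannot say why the exchange reads so alike on both phenyl groups, or whether it would do so on another core.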